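A few compounds are considered here, and "the series" means these few. Any claim that something is new, unique, unknown or untested is made for them only; others in the source may bear on it.

Measured compounds and their values in a functional assay on CHO cells with sphingosine 1-phosphate receptor 4 (Homo sapiens) as the target, read by GTPgammaS binding; on this read-out higher numbers stand for an effect only at larger amounts of compound and lower numbers for an effect already at smaller amounts:

Compound 1, `Cc1cc(CC(=O)O)ccc1-c1noc(-c2ccc(C3CCCCC3)cc2)n1`: > 10000 nM, a limit of the assay.
Compound 2, `Cc1cc(CCC(=O)O)ccc1-c1noc(-c2ccc(OC(C)C)c(C(F)(F)F)c2)n1`: > 10000 nM, a limit of the assay.
Compound 3, `CCOc1ccc(-c2nc(-c3ccc(CCC(=O)O)cc3C)no2)cc1C(F)(F)F`: > 10000 nM, a limit of the assay.

Compound 2 therefore stands at the ceiling of this assay, not at a number; it shares that position with the other two compounds, since (the limit of > 10000 nM in this assay, at which 3 of the 3 values shown sit). For the measured compounds named here, the one step among the measured compounds that differs in a single place, a step that the two limits leave unreadable from compound 2 to compound 3, runs between two such limits and its size cannot be read.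

Compound 4, `Cc1cc(CCC(=O)O)ccc1-c1noc(-c2ccc(OC(C)C)c(C#N)c2)n1`, is not yet measured. It differs from compound 2 by cyano in place of trifluoromethyl on an aromatic carbon. Going by the values given here, no measured step exchanges a cyano group for a trifluoromethyl group, so nothing among the measured compounds speaks directly to this change, and the only single-place step that is known, from compound 2 to compound 3, is unreadable. With compound 2 at the limit of this assay and every other value shown at the same limit, the expectation for compound 4 is that it too will sit at or near that limit, with a step that the limit leaves unreadable from compound 2 to compound 4 expected to be no step beyond the scatter. Compound 4 is thus estimated at 15000 nM, with a range from 4000 nM to 60000 nM.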

Compound 4, half-maximal effective concentration: > 10000 nM
Compound 4: no number, only a limit; the forecaster's own chance of this, stated with the estimate: 80%; the middle value lies beyond the limit too.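

In this assay compound 4 gives > 10000 nM, a limit of the assay and not a number. The change from compound 2 to compound 4, cyano in place of trifluoromethyl, therefore yields no readable step: the limit of > 10000 nM in this assay, at which 4 of the 4 values shown sit.

The compounds shown leave open how these two groups compare, and whether any close relative of these compounds would give a number in this assay.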